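From dimethylphenyl to dichlorophenyl: an expected small step

This account rests on a few compounds, and the source may have more. Where it says the series, first, only, none or still open, it means among the compounds named here.

The measured compounds:
- Compound 1 `Cc1ccc(-n2nc(-c3ccc(C(F)(F)F)cc3O)nc2-c2ccccc2O)cc1`, which in a functional assay on PC-12 cells (Rattus norvegicus) for cytotoxicity, read by MTT assay, with stated times of 2 h and 24 h, tested at 5 uM (on this read-out higher numbers stand for a stronger effect at the one concentration tested and lower numbers for a weaker effect), gives 94.1%
- Compound 2 `Oc1cc(C(F)(F)F)ccc1-c1nc(-c2ccccc2O)n(-c2ccccc2F)n1`, which in this assay gives 86.6%
- Compound 3 `Cc1ccc(-n2nc(-c3ccc(C(F)(F)F)cc3O)nc2-c2ccccc2O)c(C)c1`, which in this assay gives 93.3%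

All three numbers lie close together. Compound 3 sits near compound 1, with a number 0.8 percentage points lower from compound 1 to compound 3 (within the scatter), and near compound 2, with a number 6.7 percentage points higher from compound 2 to compound 3 (within the scatter); neither gap is beyond the scatter. Compound 4 `Oc1cc(C(F)(F)F)ccc1-c1nc(-c2ccccc2O)n(-c2ccc(Cl)cc2Cl)n1` is not yet measured. It differs from compound 3 in one place: 2,4-dichlorophenyl in place of 2,4-dimethylphenyl on an aromatic nitrogen.

Among the measured compounds shown here, the steps that bear on this change are those that swap the group on the aromatic nitrogen. From compound 1 to compound 2 there is a number 7.5 percentage points lower from compound 1 to compound 2 (within the scatter), and from compound 2 to compound 3 there is a number 6.7 percentage points higher from compound 2 to compound 3 (within the scatter). Both are small, so exchanging this group has so far moved the read-out only within the scatter. The expected step of a number 4.3 percentage points lower from compound 3 to compound 4 (within the scatter) is therefore small as well, with no clear direction. Compound 4 is estimated to give 89% in this assay, with a range from 76% to 98%.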

Compound 4, a percentage reported as activity, at one concentration (the size of the read-out at that concentration, not a potency): 86.7%
Beside the measured number, compound 4's estimate is 2.3 percentage points above it, within the range that was stated.
By their numbers in this assay, from the lowest: compounds 2, 4, 3 and 1 (each within the scatter of the next).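

Placing 2,4-dichlorophenyl on the aromatic nitrogen instead of 2,4-dimethylphenyl gives a number 6.6 percentage points lower from compound 3 to compound 4 (within the scatter) in this assay and so brings chlorine into the set of groups tested at this position. The other two comparisons agree with this, with a number 0.1 percentage points higher from compound 2 to compound 4 (within the scatter) and a number 7.4 percentage points lower from compound 1 to compound 4 (within the scatter), so among these four compounds, the phenyl rings carrying methyl, fluorine or chlorine cannot be told apart on this read-out. No measurement shown accounts for how closely these numbers agree.

Going by these compounds, all four groups at this position are substituted phenyl rings, so it remains open whether a different kind of group, such as a benzyl group or a phenyl ring bearing a carboxylic acid or an amine, would move the number beyond the scatter. The read-out at one concentration also leaves open whether these compounds would separate at other concentrations.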